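Furan-2-yl in Place of 2-Chlorophenyl: What to Expect

The compounds below may be only part of what the source reports. "The series", "measured", "known", "first", "only" and "open" are said of these compounds alone.

Measured in a functional assay on A549 cells (Homo sapiens) for inhibition, read by MTT assay, with a stated time of 24 h; a higher number here means a weaker inhibitor, a lower number a stronger inhibitor:
compound 1, `CCOC(=O)c1c(C)[nH]c(=O)c(C#N)c1-c1ccccc1`: > 100000 nM, a limit of the assay
compound 2, `CCOC(=O)c1c(C)[nH]c(=O)c(C#N)c1-c1ccc(Br)cc1`: > 100000 nM, a limit of the assay
compound 3, `CCOC(=O)c1c(C)[nH]c(=O)c(C#N)c1-c1ccccc1Cl`: 25000 nM

Among the compounds with values here, compound 3 holds the only number given in this assay; the other two values are limits. Compound 4 is `CCOC(=O)c1c(C)[nH]c(=O)c(C#N)c1-c1ccco1`, and it differs from compound 3 in one place: furan-2-yl in place of 2-chlorophenyl on an aromatic carbon.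

Within the data shown here, two measured steps bear on this change. There was an at least 4.0-fold lower number from compound 1 to compound 3 (0.60 log units; beyond the scatter) and an at least 4.0-fold lower number from compound 2 to compound 3 (0.60 log units; beyond the scatter), while a step that the two limits leave unreadable from compound 1 to compound 2. Both readable steps show that going from an unsubstituted or 4-bromo phenyl to the 2-chlorophenyl gave at least a modest gain. Among the measured compounds shown here, no measured step swaps the phenyl for a five-membered heteroaryl, so the direction for compound 4 is not fixed by any single comparison; yet because two of the three values sit at the limit of > 100000 nM in this assay, at which 2 of the 3 values shown sit, the removal of the 2-chlorophenyl is expected to cost potency. The number for compound 4 is therefore estimated to be higher in this assay, the step being a 2.4-fold higher number from compound 3 to compound 4 (0.38 log units; beyond the scatter). Compound 4 is estimated at 60000 nM, within 20000 nM to 200000 nM.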

Compound 4, half-maximal inhibitory concentration: > 100000 nM
Compound 4: only a limit was reported (the forecaster's own chance of this, stated with the estimate: 45%); middle value at least 1.6-fold (0.22 log units) away from the limit.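

In this assay, furan-2-yl does not keep what 2-chlorophenyl gave on this carbon, opposite the ring nitrogen; the step is an at least 4.0-fold higher number from compound 3 to compound 4 (0.60 log units; beyond the scatter). Within the data shown here, the earlier compounds compared only phenyl groups, and this result extends the loss to a five-membered aromatic ring with 1 hetero atom, leaving compound 3 as the only compound with a number rather than a limit: the limit of > 100000 nM in this assay, at which 3 of the 4 values shown sit. The steps from compound 1 and from compound 2 to compound 4 cannot be read, since both ends of each are limits.

On these data alone, how far compound 4 lies beyond its limit stays open, so furan-2-yl cannot be ranked against phenyl or 4-bromophenyl. Also open, as far as these compounds go, is whether 2-fluorophenyl, 2-methoxyphenyl or thiophen-2-yl on this carbon would give a readable number in this assay.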